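Replacing 2-oxoimidazolidin-1-yl with an open chain

This account rests on a few compounds, and the source may have more. Where it says the series, first, only, none or still open, it means among the compounds named here.

Measured in an ADME assay on microsomes from liver (Homo sapiens) for metabolic stability; on this read-out higher numbers stand for a longer-lived compound and lower numbers for a shorter-lived compound:
- Compound 1 `CC(C)C(c1cnc(N)s1)c1ccc(-c2ccc3cccc(F)c3c2)[nH]c1=O`: 0.178 h
- Compound 2 `CC(C)C(c1noc(=O)[nH]1)c1ccc(-c2ccc3cccc(F)c3c2)[nH]c1=O`: > 3 h
- Compound 3 `CC(C)C(c1ccc(-c2ccc3cccc(F)c3c2)[nH]c1=O)N1CCNC1=O`: 1.03 h

The value of compound 2, > 3 h, is a limit and not a number. Of the two true numbers, compound 3 holds the higher, at 1.03 h.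

Compound 4 `CC(C)NC(=O)CC(c1ccc(-c2ccc3cccc(F)c3c2)[nH]c1=O)C(C)C` carries (isopropylcarbamoyl)methyl in place of 2-oxoimidazolidin-1-yl on a saturated chain carbon bound to an aromatic carbon and a saturated chain carbon. Three steps at this place bear on it: the modest 5.8-fold higher number from compound 1 to compound 3 (0.76 log units; beyond the scatter), the at least modest an at least 2.9-fold lower number from compound 2 to compound 3 (0.46 log units; beyond the scatter) and the large at least 16-fold higher number from compound 1 to compound 2 (1.22 log units; beyond the scatter). All of these groups contain a ring, so none tests a group with no ring. Though with little certainty, the step is therefore expected to be modest and is estimated to be a 2.3-fold lower number from compound 3 to compound 4 (0.36 log units; beyond the scatter). For compound 4 the estimated value is 0.45 h, within a range of 0.15 h to 1.4 h.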

Compound 4, half-life: 0.32 h
Estimate against measurement, compound 4: 1.4-fold (0.15 log units) above; low and high end bracket the measured number.
By their numbers in this assay, from the lowest: compounds 1 and 4 (each within the scatter of the next); then compound 3. At a limit, above all of these: compound 2.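

In this assay, going by these compounds alone, (isopropylcarbamoyl)methyl, the only group here with no ring at this place, gives a 3.2-fold lower number from compound 3 to compound 4 (0.51 log units; beyond the scatter), so this open chain does not keep the number of 2-oxoimidazolidin-1-yl. Against 2-amino-1,3-thiazol-5-yl it shows a 1.8-fold higher number from compound 1 to compound 4 (0.25 log units; within the scatter), so these two groups cannot be told apart on this read-out. A limit and not a number lies behind an at least 9.3-fold lower number from compound 2 to compound 4 (0.97 log units; beyond the scatter).

On these data alone, whether a shorter chain, an amine or a carboxylic acid at this place would follow this one open chain stays open. So does the true value behind that limit.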